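The source may hold more compounds than are shown below. What is called first, only, known or untested is meant among the compounds shown, and "the series" means these compounds.

Three compounds share one core and differ only in the aryl group on the carbon with a double bond to nitrogen. Compound 1 `CN(C)CCn1cnnc1-c1cc(Oc2ccc(NC(=O)N/N=C/c3ccc(O)c(O)c3)cc2F)ccn1` gives 1890 nM in a functional assay on HT-29 cells (Homo sapiens) for cytotoxicity, read by MTT assay, with a stated time of 72 h; a higher number here means a weaker inhibitor, a lower number a stronger inhibitor. Compound 2 `COc1ccc(/C=N/NC(=O)Nc2ccc(Oc3ccnc(-c4nncn4CCN(C)C)c3)c(F)c2)cc1O` gives 960 nM in this assay, a step of a 2.0-fold lower number from compound 1 to compound 2 (0.29 log units; within the scatter). Compound 3 `COc1ccc(/C=N/NC(=O)Nc2ccc(Oc3ccnc(-c4nncn4CCN(C)C)c3)c(F)c2)c(OC)c1OC` gives 3970 nM in this assay, the highest of the three numbers, so it is the weakest inhibitor of the set; the steps onto it were a 2.1-fold higher number from compound 1 to compound 3 (0.32 log units; beyond the scatter) and a 4.1-fold higher number from compound 2 to compound 3 (0.62 log units; beyond the scatter). Compound 4 `CN(C)CCn1cnnc1-c1cc(Oc2ccc(NC(=O)N/N=C/c3ccccc3)cc2F)ccn1` differs from compound 3 in one place: phenyl in place of 2,3,4-trimethoxyphenyl on a carbon with a double bond to nitrogen. Both steps onto compound 3 bear on this change, since each alters the same aryl group, and each raised the number modestly. Within the data shown here, the change to compound 4 strips that aryl group bare rather than exchanging one oxygen substitution for another, so the earlier steps give no clear direction, only a hint that compound 3 sits at the weak end. Compound 4 is therefore expected to show a step of a 1.6-fold lower number from compound 3 to compound 4 (0.20 log units; within the scatter). The estimate for compound 4 in this assay is 2500 nM, within a range from 800 nM to 8000 nM.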

Compound 4, half-maximal inhibitory concentration: 1120 nM
Estimate against measurement, compound 4: 2.2-fold (0.35 log units) above, within the range that was stated.
By their numbers in this assay, from the lowest: compounds 2, 4 and 1 (each within the scatter of the next); then compound 3.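

In this assay, the plain phenyl on the carbon with a double bond to nitrogen gives a 3.5-fold lower number from compound 3 to compound 4 (0.55 log units; beyond the scatter), which ties the high number of compound 3 to its 2,3,4-trimethoxyphenyl group rather than to the shared core. Set against the hydroxy-bearing aryl groups, phenyl gives a 1.2-fold higher number from compound 2 to compound 4 (0.07 log units; within the scatter) and a 1.7-fold lower number from compound 1 to compound 4 (0.23 log units; within the scatter), so among these compounds this position holds its level with no oxygen substituent at all, and only compound 3 goes against that. No measurement here bears on why the trimethoxyphenyl group differs from the others.

The compounds shown leave open whether a lone methoxy group on the phenyl would already raise the number. They also leave open how a phenyl carrying an amine, a carboxylic acid or a chlorine atom would read at this position.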